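Urea series: trifluoromethyl on the benzyl ring

A few compounds are considered here, and "the series" means these few. Any claim that something is new, unique, unknown or untested is made for them only; others in the source may bear on it.

Measured compounds:
compound 1, `O=C(NCc1ccc(N2CCCCCC2)cc1)Nc1cccc2cnccc12` — 3.3 nM
compound 2, `Nc1cc2c(NC(=O)NCc3ccc(N4CCCCCC4)cc3)cccc2cn1` — 9.8 nM

For the measured compounds named here, in a functional assay for antagonist activity at transient receptor potential cation channel subfamily V member 1 (Homo sapiens), read by calcium flux (a higher number here means a weaker inhibitor, a lower number a stronger inhibitor), compound 1 gives 3.3 nM, the lowest of the two numbers so far; the nearest is compound 2, which gives 9.8 nM. Going by the values given here, the single measured step, a 3.0-fold higher number from compound 1 to compound 2 (0.47 log units; beyond the scatter), concerns the core of compound 1. Compound 3, `O=C(NCc1ccc(N2CCCCCC2)c(C(F)(F)F)c1)Nc1cccc2cnccc12`, carries a different change: trifluoromethyl in place of hydrogen on an aromatic carbon. Among the compounds with values here, this sits on the benzyl ring, ortho to an azepan-1-yl group, and no measured step touches that ring, so the one step recorded gives no direct guide to the size of the change. With nothing to point either way, the expectation for compound 3 is a number close to that of compound 1, with no step beyond the scatter. For compound 3 the estimate in this assay is 4.5 nM, with a range from 1.5 nM to 14 nM. That estimate corresponds to an expected step of a 1.4-fold higher number from compound 1 to compound 3 (0.13 log units; within the scatter).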

Compound 3, half-maximal inhibitory concentration: 4.6 nM
For compound 3 the middle estimate is 1.0-fold (0.01 log units) below the measured one, within the range that was stated.
By their numbers in this assay, from the lowest: compounds 1 and 3 (each within the scatter of the next); then compound 2.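

On the benzyl ring, trifluoromethyl in place of hydrogen on the aromatic carbon ortho to an azepan-1-yl group gives a 1.4-fold higher number from compound 1 to compound 3 (0.14 log units; within the scatter) in this assay and so leaves the number within the scatter of compound 1. For the compounds shown here, this is the first measured step on that ring, and the added 4 heavy atoms do not move the number beyond the scatter, whereas the change on the core gives a 3.0-fold higher number from compound 1 to compound 2 (0.47 log units; beyond the scatter) and does. No measured evidence bears on the origin of this result.

From the compounds shown here alone, whether chlorine, methoxy or nitrile on the same carbon would also stay within the scatter of compound 1 remains open, as does the outcome with an amine or a carboxylic acid there. Also open, going by these compounds, is whether trifluoromethyl at this position would give a similar step on the amino-bearing core of compound 2.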